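The compounds below may be only part of what the source reports. "The series", "measured", "known", "first", "only" and "open" are said of these compounds alone.

Measured in an ADME assay (liver) for metabolic stability, with Liver microsome (Rattus norvegicus) as the target, using microsomes and NADPH, with a stated time of 30 min, tested at 1 uM; on this read-out lower numbers stand for slow clearance and higher numbers for fast clearance:
- compound 1 `Nc1ccc(S(=O)(=O)N2CCN(c3ncc(C(O)(C(F)(F)F)C(F)(F)F)cc3-c3cnccc3F)CC2)cn1`: 22 mL.min-1.g-1
- compound 2 `Cc1ccc(-c2cc(C(O)(C(F)(F)F)C(F)(F)F)cnc2N2CCN(S(=O)(=O)c3ccc(N)nc3)CC2)cn1`: 182 mL.min-1.g-1
- compound 3 `Nc1ccc(S(=O)(=O)N2CCN(c3ncc(C(O)(C(F)(F)F)C(F)(F)F)cc3-c3ccc4scnc4c3)CC2)cn1`: 147 mL.min-1.g-1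

Compound 3 cannot be told apart from compound 2 (a 1.2-fold lower number from compound 2 to compound 3 (0.09 log units; within the scatter)), and it stands well clear of compound 1 (a 6.7-fold higher number from compound 1 to compound 3 (0.82 log units; beyond the scatter)). Compound 4 `Nc1ccc(S(=O)(=O)N2CCN(c3ncc(C(O)(C(F)(F)F)C(F)(F)F)cc3-c3cc4ccccc4[nH]3)CC2)cn1` carries 1H-indol-2-yl in place of 1,3-benzothiazol-5-yl on an aromatic carbon. Within the data shown here, no measured compound contains 1H-indol-2-yl, so the evidence is indirect. Leaving 4-fluoropyridin-3-yl gave modest steps, an 8.3-fold higher number from compound 1 to compound 2 (0.92 log units; beyond the scatter) and a 6.7-fold higher number from compound 1 to compound 3 (0.82 log units; beyond the scatter), while exchanging one replacement for another gave only a 1.2-fold lower number from compound 2 to compound 3 (0.09 log units; within the scatter). Compound 4 is a further exchange of that second kind, so no step beyond the scatter is expected. The estimated step is a 1.0-fold higher number from compound 3 to compound 4 (0.01 log units; within the scatter). For compound 4 the estimate is 150 mL.min-1.g-1, with an expected range from 60 mL.min-1.g-1 to 350 mL.min-1.g-1.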

Compound 4, intrinsic clearance in microsomes: 146 mL.min-1.g-1
Beside the measured number, compound 4's estimate is 1.0-fold (0.01 log units) above it; measured number inside the range.
By their numbers in this assay, from the lowest: compound 1; then compounds 4, 3 and 2 (each within the scatter of the next).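

In this assay, the aromatic carbon ortho to a large group now carries 1H-indol-2-yl, which has a hydrogen-bond donor that 1,3-benzothiazol-5-yl lacks, yet the exchange gives a 1.0-fold lower number from compound 3 to compound 4 (0.00 log units; within the scatter). The comparison with 6-methylpyridin-3-yl also stays within the scatter, at a 1.2-fold lower number from compound 2 to compound 4 (0.10 log units; within the scatter), and among these four compounds only 4-fluoropyridin-3-yl stands apart, with a 6.6-fold higher number from compound 1 to compound 4 (0.82 log units; beyond the scatter). Going by these compounds, whether an amine or a carboxylic acid on this carbon would group with compound 1 or with the other three remains open. Nothing measured here accounts for this pattern.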